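A few compounds are considered here, and "the series" means these few. Any claim that something is new, unique, unknown or untested is made for them only; others in the source may bear on it.

Compound 1 `N#Cc1ccc(C(=O)NCC(=O)N/N=C/c2ccccc2OCc2ccccc2Cl)cc1`: in a functional assay on HepG2 cells (Homo sapiens) for inhibition, read by MTT assay, with a stated time of 24 h (a lower number here means a stronger inhibitor, a higher number a weaker inhibitor), compound 1 gives > 50000 nM, which is a limit of the assay and not a number.
Compound 2 `COc1ccc(/C=N/NC(=O)CNC(=O)c2ccc(C)cc2)c(OCc2ccccc2Cl)c1`: compound 2 gives > 50000 nM, again a limit of the assay.
Compound 3 `COc1ccc(/C=N/NC(=O)CNC(=O)c2ccc(F)cc2)c(OCc2ccccc2Cl)c1`: compound 3 gives 15700 nM.

Within the data shown here, compound 3 therefore stands alone as the only measured number among the three; the other two compounds sit at the limit of > 50000 nM in this assay, at which 2 of the 3 values shown sit, so no order among them can be read. Among the measured compounds shown here, the one measured step is an at least 3.1-fold lower number from compound 2 to compound 3 (0.50 log units; beyond the scatter), which moved compound 3 from the limit to a measurable number.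

Compound 4 `COc1ccc(/C=N/NC(=O)CNC(=O)c2ccc(C#N)cc2)c(OCc2ccccc2Cl)c1` is not yet measured. It differs from compound 3 in one place: cyano in place of fluoro on an aromatic carbon. For the measured compounds named here, compound 1 also carries a cyano group on the corresponding ring but lacks the methoxy group of compound 3 and compound 4, so no measured step connects it to compound 4; it only shows that one cyano-bearing compound sits at the limit. Nothing measured bears directly on the exchange of fluoro for cyano. Given that compound 1 gives > 50000 nM, a limit, and that compound 3 is the sole number, the expected outcome for compound 4 is a weakening, a 2.2-fold higher number from compound 3 to compound 4 (0.35 log units; beyond the scatter), with a fair chance that only a limit is reported. Compound 4 is estimated at 35000 nM, in the range 10000 nM to 120000 nM.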

Compound 4, half-maximal inhibitory concentration: > 50000 nM
Compound 4: no number, only a limit; the forecaster's own chance of this, stated with the estimate: 45%; at least 1.4-fold (0.15 log units) between middle value and limit.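

Cyano in place of fluoro on the aromatic carbon, para to a large group, gives an at least 3.1-fold higher number from compound 3 to compound 4 (0.50 log units; beyond the scatter) in this assay, so the measurable inhibition of compound 3 does not survive this exchange. Compound 4 gives only a limit of the assay and not a number, so the step has a lower bound but no known full size. Of methyl, fluoro and cyano at this place on the core of compound 3, only fluoro now gives a number, with a change on each side of it, and the rest of the compounds shown share one limit: the limit of > 50000 nM in this assay, at which 3 of the 4 values shown sit.

The steps to compound 4 from compound 2 and from compound 1 cannot be read, as both ends of each are limits, which leaves any order among methyl, cyano and the compound without the methoxy group unknown. Going by these compounds, whether a bromo group or an amine on this aromatic carbon would give a number, and whether any group here would give a lower number than fluoro, remains open.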